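Replacing sulfo with ethoxycarbonyl on the chain of compound 3

A few compounds are considered here, and "the series" means these few. Any claim that something is new, unique, unknown or untested is made for them only; others in the source may bear on it.

Measured in a functional assay for inhibition; on this read-out higher numbers stand for weaker inhibition and lower numbers for stronger inhibition
compound 1 `CC(C)(C)c1cc(-c2cc(=O)c3ccc(OCC(=O)N4CCN(Cc5ccccc5)CC4)cc3o2)cc(C(C)(C)C)c1O` gives 3000 nM
compound 2 `CC(C)(C)c1cc(-c2cc(=O)c3ccc(OCc4ccc5ccccc5n4)cc3o2)cc(C(C)(C)C)c1O` gives 3000 nM
compound 3 `CC(C)(C)c1cc(-c2cc(=O)c3ccc(OCCCS(=O)(=O)O)cc3o2)cc(C(C)(C)C)c1O` gives 500 nM

Compound 3 has the lowest number of the three, with compound 1 and compound 2 both higher beyond the scatter. Compound 4 `CCOC(=O)CCCCOc1ccc2c(=O)cc(-c3cc(C(C)(C)C)c(O)c(C(C)(C)C)c3)oc2c1` differs from it thus: (ethoxycarbonyl)methyl in place of sulfo on a saturated chain carbon, three bonds along the chain from an oxygen on an aromatic ring. Within the data shown here, the one measured step bearing on this change is a 6.0-fold lower number from compound 2 to compound 3 (0.78 log units; beyond the scatter), a modest one. Among the measured compounds shown here, compound 4 has no sulfo group, and neither does compound 1 at 3000 nM or compound 2 at 3000 nM, so a modest rise is expected in this assay, though only three compounds support this. The expected change is a 3.0-fold higher number from compound 3 to compound 4 (0.48 log units; beyond the scatter), short of the full gap. The estimate for compound 4 is 1500 nM, with an expected range from 500 nM to 5000 nM.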

Compound 4, half-maximal inhibitory concentration: 3000 nM
For compound 4 the middle estimate is 2.0-fold (0.30 log units) below the measured one, within the range that was stated.
By their numbers in this assay, from the lowest: compound 3; then compounds 1, 2 and 4 (each within the scatter of the next).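

In this assay, moving from the sulfo end to the ester end gives a 6.0-fold higher number from compound 3 to compound 4 (0.78 log units; beyond the scatter) and so takes away the advantage compound 3 held at this position. Set against the quinolin-2-yl ether, the 3-(ethoxycarbonyl)propyl chain gives no change at the digits printed from compound 2 to compound 4 (within the scatter) so that, of the two chains, only the sulfo-ended one stands apart from compound 2. Nothing measured here explains this gap. Still open, going by these compounds, is whether a carboxylic acid at the chain end, or a sulfo group on a longer chain, would match compound 3.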